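Series notes: aryl swap on a ring amine nitrogen

A few compounds are considered here, and "the series" means these few. Any claim that something is new, unique, unknown or untested is made for them only; others in the source may bear on it.

Compound 1 `COc1ccc(N2CCN(C(=S)SCc3ccc(C(=O)Nc4ccccc4N)cc3)CC2)cc1`: 35.9%
Compound 2 `CC1CCCCN1C(=S)SCc1ccc(C(=O)Nc2ccccc2N)cc1`: 85.2%

Both numbers come from a functional assay on A-375 cells (Homo sapiens) for antiproliferative activity, read by CCK-8 assay, with a stated time of 72 h, tested at 8 uM; a lower number here means a weaker effect, a higher number a stronger effect of the compound at the concentration tested. Compound 1 holds the lower of the two values, and compound 2 stands higher by a margin beyond the usual scatter. Among the compounds with values here, no two measured compounds differ in only one place, so no single step is known yet. Compound 3 `Nc1ccccc1NC(=O)c1ccc(CSC(=S)N2CCN(c3ccncc3)CC2)cc1` is unmeasured; it differs from compound 1 in this way: pyridin-4-yl in place of 4-methoxyphenyl on an amine nitrogen in a ring. Within the data shown here, with no comparable step measured, the step of a number 9.1 percentage points higher from compound 1 to compound 3 (within the scatter) is expected to be small, a modest rise at most, possibly within the scatter. For compound 3 the expected value is 45%, with a range from 20% to 75%.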

Compound 3, a percentage reported as inhibition, at one concentration (the size of the read-out at that concentration, not a potency): 90.7%
Compound 3: the middle estimate sits 45.7 percentage points below what was measured, outside the stated range (above it).
By their numbers in this assay, from the lowest: compound 1; then compounds 2 and 3 (each within the scatter of the next).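

In this assay, pyridin-4-yl in place of 4-methoxyphenyl on the amine nitrogen in the ring gives a number 54.8 percentage points higher from compound 1 to compound 3 (beyond the scatter). This position is therefore sensitive: exchanging one six-membered aromatic ring for another is enough to change the read-out at the tested concentration beyond the scatter. No available evidence explains the step.

The pair does not separate the effect of the ring nitrogen from that of losing the methoxy group; plain phenyl would address this. As far as these compounds go, whether pyridin-3-yl or pyridin-2-yl behaves like pyridin-4-yl also remains open.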